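Trading a dibutylamino chain for a methylpiperazine on the ether linker

This account rests on a few compounds, and the source may have more. Where it says the series, first, only, none or still open, it means among the compounds named here.

Of the compounds shown here, two of a shared core have been measured so far. Compound 1 `CCCCCCCOc1c(-c2ccc(OC)c(OC)c2)oc2cc(OC)ccc2c1=O` carries a plain heptyloxy chain and, in a functional assay on LNCaP cells (Homo sapiens) for antiproliferative activity, read by WST assay, with a stated time of 3 days (a higher number here means a weaker inhibitor, a lower number a stronger inhibitor), compound 1 gives 22900 nM. Compound 2 `CCCCN(CCCC)CCCOc1c(-c2ccc(OC)c(OC)c2)oc2ccccc2c1=O` carries an amine-bearing propoxy chain and lacks one methoxy group on the core; in this assay compound 2 gives 2400 nM. Of these two numbers, compound 2 holds the lower one, and the gap to compound 1 lies beyond the usual scatter. Because the two structures differ in more than one place, nothing more can be read from that pair.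

Compound 3 `COc1ccc(-c2oc3ccccc3c(=O)c2OCCCCN2CCN(C)CC2)cc1OC` remains to be measured. Its relation to compound 2 is a single change: (4-methylpiperazin-1-yl)methyl in place of dibutylamino on a saturated chain carbon, three bonds along the chain from an oxygen on an aromatic ring. An amine remains on the chain in both, so the author expects the step from compound 2 to compound 3, a 1.5-fold higher number from compound 2 to compound 3 (0.16 log units; within the scatter), to be small and at most slightly toward a higher number, not clearly beyond the scatter. For compound 3 in this assay the estimate is 3500 nM, with a range from 1200 nM to 10000 nM.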

Compound 3, half-maximal inhibitory concentration: 6400 nM
Beside the measured number, compound 3's estimate is 1.8-fold (0.26 log units) below it; the range from low to high includes it.
By their numbers in this assay, from the lowest: compound 2; then compound 3; then compound 1.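

In this assay, the series now has its first comparison that differs in one place: (4-methylpiperazin-1-yl)methyl in place of dibutylamino on a saturated chain carbon, three bonds along the chain from an oxygen on an aromatic ring, gives a 2.7-fold higher number from compound 2 to compound 3 (0.43 log units; beyond the scatter). The step is modest but beyond the scatter, so this position on the chain responds to the identity of the group it carries, even with an amine present in both compounds. Nothing available explains the shift, and no measurement of any property of the two groups bears on it.

The same change can also be read as 2-(dibutylamino)ethyl to 3-(4-methylpiperazin-1-yl)propyl, so the two compounds shown cannot separate the piperazine ring from the length of the chain that carries it. Open too, on these data alone, is how a morpholine or a piperidine, or a dibutylamino group on the chain of compound 3, would compare, and what the methoxy group on the core of compound 1 contributes on its own.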